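The source may report more compounds than this note shows. Statements on the series, on what has been measured and on what is new or still open speak of the compounds shown alone.

Working notes on the series. Compound 3 `COc1ccc(C=C2C(=O)N(c3ccc(Cl)cc3)N(c3ccc(Cl)cc3)C2=O)cc1OC` stands in a functional assay on SMMC-7721 cells (Homo sapiens) for cytotoxicity, read by MTT assay, with a stated time of 72 h (a lower number here means a stronger inhibitor, a higher number a weaker inhibitor), at > 128000 nM, which is a limit and not a number. Compound 1 `CN(C)c1ccc(C=C2C(=O)N(c3ccc(Cl)cc3)N(c3ccc(Cl)cc3)C2=O)cc1` reads > 128000 nM, also a limit. So the limit of > 128000 nM in this assay, at which 2 of the 3 values shown sit, describes two of the three readings. For the measured compounds named here, compound 2 `O=C1C(=Cc2ccc(Cl)cc2)C(=O)N(c2ccc(Cl)cc2)N1c1ccc(Cl)cc1` gives 30900 nM, the only actual number so far.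

Compound 4 `O=C1C(=Cc2ccc(F)cc2F)C(=O)N(c2ccc(Cl)cc2)N1c1ccc(Cl)cc1` keeps the shared core and changes only the aryl group: 2,4-difluorophenyl in place of 3,4-dimethoxyphenyl on a double-bonded chain carbon bound to a double-bonded ring carbon. Thus 2,4-difluorophenyl replaces 3,4-dimethoxyphenyl on a double-bonded chain carbon bound to a double-bonded ring carbon.

Going by the values given here, two measured steps bear on this change. The closest is an at least 4.1-fold higher number from compound 2 to compound 3 (0.61 log units; beyond the scatter), where the same 3,4-dimethoxyphenyl group replaces 4-chlorophenyl. The other is an at least 4.1-fold lower number from compound 1 to compound 2 (0.61 log units; beyond the scatter), which points the same way. Both sizes are bounded by a limit, so neither is a full measure. Among these three compounds, only compound 2, with a halogen on this aryl group, falls inside the measurable range, and a single compound is thin support.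

A modest move toward a lower number in this assay is therefore expected, though compound 4 could also stay at the limit. The expected change is an at least 2.3-fold lower number from compound 3 to compound 4 (0.36 log units; beyond the scatter). The estimate for compound 4 is 55000 nM, with an expected range of 15000 nM to 128000 nM.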

Compound 4, half-maximal inhibitory concentration: 35800 nM
Estimate against measurement, compound 4: 1.5-fold (0.19 log units) above; the measured number falls inside the stated range.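

In this assay, 2,4-difluorophenyl on a double-bonded chain carbon bound to a double-bonded ring carbon puts a second compound inside the measurable range, so compound 2 no longer stands alone there: the change from 3,4-dimethoxyphenyl gives an at least 3.5-fold lower number from compound 3 to compound 4 (0.55 log units; beyond the scatter), and the change from 4-(dimethylamino)phenyl gives an at least 3.5-fold lower number from compound 1 to compound 4 (0.55 log units; beyond the scatter). Replacing 4-chlorophenyl with 2,4-difluorophenyl gives a 1.2-fold higher number from compound 2 to compound 4 (0.06 log units; within the scatter), so these two halogen-bearing aryl groups cannot be told apart in this assay. The two larger steps remain bounded, and the step between compound 1 and compound 3 cannot be read, because each of those compounds sits at a limit: the limit of > 128000 nM in this assay, at which 2 of the 4 values shown sit.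

The link between halogen-bearing aryl groups and a measurable reading rests on only compound 2 and compound 4, with compound 1 and compound 3 as the contrast and no compound shown against it, so it remains open whether an unsubstituted phenyl, a 4-methylphenyl or a 4-nitrophenyl group would also read inside the range. Also open, as far as these compounds go, is how far compound 1 and compound 3 actually lie from that measured pair.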